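The source may report more compounds than this note shows. Statements on the series, on what has been measured and on what is new or still open speak of the compounds shown alone.

In an ADME assay on S9 fraction from S9 cells (Zone of skin, Homo sapiens) for metabolic stability, read by HPLC, with a stated time of 180 min, tested at 0.5 uM (a higher number here means that the compound lasts longer, a lower number that the compound disappears faster), compound 1 `CCC/N=C1\S/C(=C\c2ccc(OC(=O)C(C)(C)C)c(C)c2)C(=O)N1c1ccccc1C` gives > 3 h, which is a limit of the assay and not a number. Among the compounds with values here, compound 2 `CCC/N=C1\S/C(=C\c2ccc(OC(C)=O)c(Br)c2)C(=O)N1c1ccccc1C` gives 0.147 h, the only actual number so far. Compound 3 `CCC/N=C1\S/C(=C\c2ccc(OC(C)=O)c(C(F)(F)F)c2)C(=O)N1c1ccccc1C` differs from compound 2 by trifluoromethyl in place of bromo on an aromatic carbon, ortho to an acetoxy group. Within the data shown here, no measured step bears on this change. The expected step of a 1.1-fold lower number from compound 2 to compound 3 (0.02 log units; within the scatter) in this assay is therefore none beyond the scatter, with neither direction favoured. For compound 3 the estimated half-life is 0.14 h, with an expected range of 0.06 h to 0.35 h.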

Compound 3, half-life: 0.138 h
Compound 3: the middle estimate sits 1.0-fold (0.01 log units) above what was measured; measured number inside the range.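

Trifluoromethyl in place of bromo on an aromatic carbon, ortho to an acetoxy group, gives a 1.1-fold lower number from compound 2 to compound 3 (0.03 log units; within the scatter) in this assay. Within the data shown here, this is the first step that can be read, and at this position the exchange leaves the half-life within the scatter. The two groups are not told apart by this read-out.

Compound 1 differs from compound 2 and compound 3 in more than one place, and its value is a limit of the assay, not a number: the limit of > 3 h in this assay, at which 1 of the 3 values shown sits.

Going by these compounds, whether a nitrile or a methoxy group at this position, or an amide in place of the acetoxy group, would move the half-life beyond the scatter stays open.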